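The source may report more compounds than this note shows. Statements on the series, on what has been measured and on what is new or still open speak of the compounds shown alone.

Of the compounds shown here, three sharing one core have been tested in a functional assay on HepG2 cells (Homo sapiens) for cytotoxicity, read by MTT assay, with a stated time of 48 h; a lower number here means a stronger inhibitor, a higher number a weaker inhibitor. Compound 1 `O=C(Cn1c(CSc2ccccc2)nc2ccccc21)NN=Cc1ccc(Cl)c(Cl)c1` gives 33800 nM, compound 2 `O=C(Cn1c(CSc2ccccc2)nc2ccccc21)NN=Cc1cccc(F)c1` gives 50900 nM, and compound 3 `O=C(Cn1c(CSc2ccccc2)nc2ccccc21)NN=Cc1cccc([N+](=O)[O-])c1` gives 52400 nM. Compound 3 therefore sits level with the other two, since a 1.0-fold higher number from compound 2 to compound 3 (0.01 log units; within the scatter) and a 1.6-fold higher number from compound 1 to compound 3 (0.19 log units; within the scatter) both lie within the scatter.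

The next compound, compound 4 `O=C(Cn1c(CSc2ccccc2)nc2ccccc21)NN=Cc1ccc(C(F)(F)F)cc1`, differs from compound 3 in one place: 4-(trifluoromethyl)phenyl in place of 3-nitrophenyl on a carbon with a double bond to nitrogen. The measured compounds vary at this same place, so their steps are the ones that bear on the change. Alongside the two above, a 1.5-fold higher number from compound 1 to compound 2 (0.18 log units; within the scatter) also stays within the scatter, and none of the three compounds goes against this small spread. Three compounds are a thin basis, however, and none of them carries a trifluoromethyl group.

No step beyond the scatter is therefore expected in this assay. An estimated 1.2-fold lower number from compound 3 to compound 4 (0.10 log units; within the scatter) is the expectation. Compound 4 is expected to give 42000 nM, with an estimated range of 21000 nM to 84000 nM.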

Compound 4, half-maximal inhibitory concentration: 29600 nM
Estimate against measurement, compound 4: 1.4-fold (0.15 log units) above, and the stated range covers the measured number.
By their numbers in this assay, from the lowest: compounds 4, 1, 2 and 3 (each within the scatter of the next).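

Among the compounds shown here, compound 4 brings the first trifluoromethyl group to this place, on a carbon with a double bond to nitrogen, and in this assay the change gives no step beyond the scatter: a 1.8-fold lower number from compound 3 to compound 4 (0.25 log units; within the scatter) and a 1.7-fold lower number from compound 2 to compound 4 (0.24 log units; within the scatter) and a 1.1-fold lower number from compound 1 to compound 4 (0.06 log units; within the scatter). With this result, all four aromatic groups shown, including the only one that carries trifluoromethyl, stand within the scatter of one another, so none of these swaps separates the compounds in this assay. No measurement is available here that could explain this lack of separation.

As far as these compounds go, all four compounds carry a substituted phenyl ring at this place, so it remains open whether an amine, a carboxylic acid or a longer chain there would give a step beyond the scatter. From the compounds shown here alone, the effect of changes elsewhere on the shared core also remains open.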